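A few compounds are considered here, and "the series" means these few. Any claim that something is new, unique, unknown or untested is made for them only; others in the source may bear on it.

Compound 1 `Cn1c(-c2ccc(NC(=O)CSc3nc4ccccc4o3)cc2)nc(-c2ccccc2)c1-c1ccccc1` gives 11.2 ug/mL in a functional assay on MCF7 cells (Homo sapiens) for cytotoxicity, read by MTT assay, with a stated time of 24 h; a higher number here means a weaker inhibitor, a lower number a stronger inhibitor. Compound 2 `Cn1cnnc1SCC(=O)Nc1ccc(-c2nc(-c3ccccc3)c(-c3ccccc3)n2C)cc1` gives 3.2 ug/mL. Compound 3 `Cn1ccnc1SCC(=O)Nc1ccc(-c2nc(-c3ccccc3)c(-c3ccccc3)n2C)cc1` gives 46.5 ug/mL.

Compound 3 stands highest of the three: a 4.2-fold higher number from compound 1 to compound 3 (0.62 log units; beyond the scatter) and a 15-fold higher number from compound 2 to compound 3 (1.16 log units; beyond the scatter), both beyond the scatter. Compound 4 `CCN1CCN(CC(=O)Nc2ccc(-c3nc(-c4ccccc4)c(-c4ccccc4)n3C)cc2)CC1` differs from compound 3 by 4-ethylpiperazin-1-yl in place of (1-methyl-1H-imidazol-2-yl)sulfanyl on a saturated chain carbon bound to a carbonyl carbon. For the measured compounds named here, no measured step bears directly on this change; the measured steps (a 3.5-fold lower number from compound 1 to compound 2 (0.54 log units; beyond the scatter), a 4.2-fold higher number from compound 1 to compound 3 (0.62 log units; beyond the scatter), a 15-fold higher number from compound 2 to compound 3 (1.16 log units; beyond the scatter)) all keep the sulfur and swap the ring on it, and they show that swapping this part of the molecule moves the number modestly to largely in either direction. Compound 4 is therefore expected to move by about a 2.3-fold lower number from compound 3 to compound 4 (0.37 log units; beyond the scatter), with wide uncertainty, giving an estimate of 20 ug/mL (range 5 ug/mL to 80 ug/mL).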

Compound 4, half-maximal inhibitory concentration: 80 ug/mL
Estimate against measurement, compound 4: 4.0-fold (0.60 log units) below; the range from low to high includes it.
By their numbers in this assay, from the lowest: compound 2; then compound 1; then compounds 3 and 4 (each within the scatter of the next).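

Replacing the sulfur-linked ring outright with 4-ethylpiperazin-1-yl gives a step within the scatter (a 1.7-fold higher number from compound 3 to compound 4 (0.24 log units; within the scatter)), so this group cannot be told apart from (1-methyl-1H-imidazol-2-yl)sulfanyl at this position. The other two sulfur-linked groups give clearly lower numbers (a 25-fold higher number from compound 2 to compound 4 (1.40 log units; beyond the scatter); a 7.1-fold higher number from compound 1 to compound 4 (0.85 log units; beyond the scatter)), which shows that losing the sulfur link does not by itself set the number. No evidence explaining these differences is available.

On these data alone, whether a morpholine or a carboxylic acid on the saturated chain carbon would read like 4-ethylpiperazin-1-yl stays open. So does the effect of a longer chain at this place.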